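Swapping Cyclohexyl for Isopropyl on the Shared Core

A few compounds are considered here, and "the series" means these few. Any claim that something is new, unique, unknown or untested is made for them only; others in the source may bear on it.

Values measured so far in a functional assay on KBVIN cells (Homo sapiens) for cytotoxicity, read by MTT assay, with a stated time of 72 h (a lower number here means that less compound is needed, a higher number that more compound is needed for the effect), are these:
- compound 1 `COc1ccc(Nc2cc(C3CCCCC3)oc(=O)c2)cc1` gives 4.39 uM
- compound 2 `O=c1cc(NC2CCCCC2)cc(-c2ccccc2)o1` gives 9.15 uM

Compound 1 has the lower of these two numbers, so less of it is needed for the effect, and the gap to compound 2 lies beyond the usual scatter. These two compounds do not differ in just one place, so that gap cannot be pinned on any single change.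

Compound 3 `COc1ccc(Nc2cc(C(C)C)oc(=O)c2)cc1` keeps the core of compound 1 and changes one group, with isopropyl in place of cyclohexyl on an aromatic carbon. Going by the values given here, no measured pair shows this swap alone, so any forecast in this assay is loose. A modest expected move toward a higher number (a 1.8-fold higher number from compound 1 to compound 3 (0.26 log units; within the scatter)) seems most likely, though a result within the usual scatter would be no surprise. The estimate for compound 3 is 8 uM with 3 uM to 25 uM as its expected range.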

Compound 3, concentration for half-maximal effect: > 30 uM
Compound 3: no number, only a limit; the forecaster's own chance of this, stated with the estimate: 3%; middle value at least 3.7-fold (0.57 log units) away from the limit.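

In this assay compound 3 gives > 30 uM, which is a limit of the assay and not a number. Only isopropyl in place of cyclohexyl on an aromatic carbon separates these two compounds, and the step is an at least 6.8-fold higher number from compound 1 to compound 3 (0.83 log units; beyond the scatter), so this position next to the ring oxygen matters for the read-out in a way the earlier pair, which differed in more than one place, could not show. Only a lower bound on this step can be read, not its full size: the limit of > 30 uM in this assay, at which 1 of the 3 values shown sits.

Still open, on these data alone, is whether the ring of cyclohexyl or simply the size of the group counts here, a question that a straight hexyl chain or a cyclopentyl ring at the same place would address. Also open, as far as these compounds go, is whether the swap would act the same way with a different group on the shared core's nitrogen.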